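A few compounds are considered here, and "the series" means these few. Any claim that something is new, unique, unknown or untested is made for them only; others in the source may bear on it.

Measured so far in an ADME assay on L929 cells (Mus musculus) for cytotoxicity, read by resazurin assay, with a stated time of 72 h; a lower number here means a stronger inhibitor, a higher number a weaker inhibitor:
compound 1, `O=C(c1ccccc1)c1ccn(-c2ccc3c(c2)B(O)OC3)c1`: > 10 ug/mL
compound 2, `O=C(c1cccc(Cl)c1)c1ccn(-c2ccc3c(c2)B(O)OC3)c1`: > 10 ug/mL

In this assay compound 1 gives only a limit of the assay, > 10 ug/mL. In this assay compound 2 likewise gives only a limit, > 10 ug/mL. Going by the values given here, the one step between them, chloro in place of hydrogen on an aromatic carbon, is a step that the two limits leave unreadable from compound 1 to compound 2; nothing can be read from it, since both values sit at the limit of > 10 ug/mL in this assay, at which 2 of the 2 values shown sit.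

Compound 3, `Cc1cccc(C(=O)c2ccn(-c3ccc4c(c3)B(O)OC4)c2)c1`, is the next member. It differs from compound 2 by methyl in place of chloro on an aromatic carbon, meta to a large group; cut one bond further out, 3-chlorophenyl becomes 3-methylphenyl. Among the compounds with values here, the only measured step bears on this position, and it is unreadable, so there is no measured size to carry over. With both neighbours at a limit, no step beyond the scatter is expected for compound 3 in this assay; the most likely outcome is again a limit. The estimate for compound 3 is 20 ug/mL, within 8 ug/mL to 60 ug/mL. The step this estimate means, a step that the limit leaves unreadable from compound 2 to compound 3, is expected to be negligible.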

Compound 3, half-maximal inhibitory concentration: > 10 ug/mL
Compound 3: only a limit was reported; the forecaster's own chance of this, stated with the estimate: 85%; the middle value is on the limit's open side.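

In this assay compound 3 gives only a limit, > 10 ug/mL. No step can be read among compound 1, compound 2 and compound 3, because each value is a limit: the limit of > 10 ug/mL in this assay, at which 3 of the 3 values shown sit.

The compounds shown leave open how hydrogen, chloro and methyl at this aromatic position compare in this assay, and whether any change to the shared core would give a value inside the assay's range.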